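A Chloro Group Leaves Compound 3

The source may report more compounds than this note shows. Statements on the series, on what has been measured and on what is new or still open speak of the compounds shown alone.

Measured so far in an ADME assay on HepG2 cells (Homo sapiens) for cytotoxicity, read by MTT assay, with a stated time of 72 h; on this read-out lower numbers stand for higher toxicity in this test and higher numbers for lower toxicity in this test
compound 1 `O=[N+]([O-])c1cnc2c(Br)cc(Cl)cn12` gives 16200 nM
compound 2 `Cc1nc2c(Sc3ccc(Cl)cc3)cc(Cl)cn2c1[N+](=O)[O-]` gives > 7800 nM as a limit
compound 3 `O=[N+]([O-])c1c(CS(=O)(=O)c2ccccc2)nc2c(Nc3ccc(Cl)cc3)cc(Cl)cn12` gives > 3900 nM as a limit

Compound 3 stands at > 3900 nM in this assay and this is a limit, not a number. Compound 2 stands at > 7800 nM and this too is a limit. Compound 1 is the only one of the three with a true number, at 16200 nM in this set.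

Compound 4 `O=[N+]([O-])c1c(CS(=O)(=O)c2ccccc2)nc2c(Nc3ccccc3)cc(Cl)cn12` differs from compound 3 in one place, described as hydrogen in place of chloro on an aromatic carbon in the count. In words, hydrogen stands in place of chloro on an aromatic carbon, para to a large group, so that 4-chlorophenyl becomes phenyl. Among the compounds with values here, no measured pair in the set shows a single change of this kind, so the direction of any shift stays open, and no step beyond the usual scatter is expected in this assay for this change. The expected size is a step that the limit leaves unreadable from compound 3 to compound 4, an estimate taken from the limit of compound 3 alone. The estimated value of compound 4 is 7000 nM, with an expected range from 3000 nM to 20000 nM in this test.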

Compound 4, half-maximal cytotoxic concentration: > 3900 nM
Compound 4: only a limit was reported; the forecaster's own chance of this, stated with the estimate: 65%; the middle value lies beyond the limit too.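

In this assay compound 3 and compound 4 are both reported only as limits, so no step can be read between them, because they share one limit: the limit of > 3900 nM in this assay, at which 2 of the 4 values shown sit. The compounds shown leave open whether hydrogen in place of chloro on an aromatic carbon shifts this read-out in either direction.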